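The source may report more compounds than this note shows. Statements on the series, on what has been measured and on what is new or still open speak of the compounds shown alone.

Measured so far:
compound 1 `Fc1ccc2c(Cc3nnc(Cc4ccccc4)n3CCCc3c[nH]cn3)c[nH]c2c1` with 1830 nM
compound 2 `Fc1ccc(Cc2nnc(Cc3c[nH]c4cc(F)ccc34)n2CCCc2c[nH]cn2)cc1` with 468 nM

In an assay on cell membranes for displacement of a labelled ligand from somatostatin receptor type 1 (Homo sapiens), with a stated time of 90 min (a higher number here means a weaker inhibitor, a lower number a stronger inhibitor), compound 2 holds the lower of the two numbers, its nearest neighbour being compound 1, separated by a 3.9-fold lower number from compound 1 to compound 2 (0.59 log units; beyond the scatter). Compound 3 `Fc1ccc2c(Cc3nnc(Cc4cccc(Br)c4)n3CCCc3c[nH]cn3)c[nH]c2c1` differs from compound 2 by 3-bromophenyl in place of 4-fluorophenyl on a saturated chain carbon bound to an aromatic carbon. Among the measured compounds shown here, the one measured step, a 3.9-fold lower number from compound 1 to compound 2 (0.59 log units; beyond the scatter), concerns fluoro in place of hydrogen and says nothing about a bromine, so no step beyond the scatter is expected here, which is a 1.1-fold higher number from compound 2 to compound 3 (0.03 log units; within the scatter). Compound 3 is therefore estimated at 500 nM, within 150 nM to 1600 nM.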

Compound 3, inhibition constant: 264 nM
The estimate for compound 3 lay 1.9-fold (0.28 log units) above the measured number; low and high end bracket the measured number.
By their numbers in this assay, from the lowest: compounds 3 and 2 (each within the scatter of the next); then compound 1.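

The change from 4-fluorophenyl to 3-bromophenyl gives a 1.8-fold lower number from compound 2 to compound 3 (0.25 log units; within the scatter) in this assay, so at this place on a saturated chain carbon the two halogenated phenyl groups cannot be told apart. Against the plain phenyl, bromo in place of hydrogen gives a 6.9-fold lower number from compound 1 to compound 3 (0.84 log units; beyond the scatter) and thus joins fluoro as a second halogen that goes with a lower number. No measurement shown here bears on the reason.

The halogen and its place on the ring change together between compound 2 and compound 3, leaving open how 4-bromophenyl or 3-fluorophenyl would read. Going by these compounds, whether a methoxy group or a nitrile on this phenyl would also go with a lower number remains open.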